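Replacing 4-Iodophenyl with Thiophen-3-yl: an Expected Step

The source may report more compounds than this note shows. Statements on the series, on what has been measured and on what is new or still open speak of the compounds shown alone.

Compound 3 `COc1cc(C(=O)c2sc(-c3ccc(I)cc3)cc2N)cc(OC)c1OC` is measured in a functional assay on CCRF-CEM cells (Homo sapiens) for antiproliferative activity (a lower number here means a stronger inhibitor, a higher number a weaker inhibitor), and gives 150 nM. Of the two numbers available, compound 3 has the highest; its nearest neighbour is compound 2 `COc1ccc(-c2cc(N)c(C(=O)c3cc(OC)c(OC)c(OC)c3)s2)cc1OC`, which gives 20 nM in this assay. Compound 1 `COc1cc(C(=O)c2sc(-c3ccc(-c4ccccc4)cc3)cc2N)cc(OC)c1OC` gives only a limit in this assay, > 10000 nM. Going by the values given here, two steps bear on the change at hand. One is an at least 66-fold lower number from compound 1 to compound 3 (1.82 log units; beyond the scatter), which rests on the limit (the limit of > 10000 nM in this assay, at which 1 of the 3 values shown sits). The other is a 7.5-fold higher number from compound 2 to compound 3 (0.88 log units; beyond the scatter). Both show that the group on this aromatic carbon matters strongly for potency. The step to compound 4 `COc1cc(C(=O)c2sc(-c3ccsc3)cc2N)cc(OC)c1OC` is thiophen-3-yl in place of 4-iodophenyl on an aromatic carbon. Among the compounds with values here, the group entering is smaller and carries no iodine, and no measured step tells what thiophen-3-yl does here, so the expectation is a modest weakening, possibly none beyond the scatter. Compound 4 is therefore estimated to give 400 nM, with a range from 100 nM to 2000 nM. That estimate amounts to an expected 2.7-fold higher number from compound 3 to compound 4 (0.43 log units; beyond the scatter).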

Compound 4, half-maximal inhibitory concentration: 9.6 nM
The estimate for compound 4 lay 42-fold (1.62 log units) above the measured number; the whole stated range lies above it.
By their numbers in this assay, from the lowest: compound 4; then compound 2; then compound 3. At a limit, above all of these: compound 1.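

In this assay, thiophen-3-yl in place of 4-iodophenyl gives a large gain, a 16-fold lower number from compound 3 to compound 4 (1.19 log units; beyond the scatter), so this position, next to the ring sulfur, accepts a five-membered aromatic ring with 1 hetero atom and does not need a six-membered aromatic ring of carbon only, the kind of ring that every earlier compound carries there. Going by these compounds alone, the new group also edges past 3,4-dimethoxyphenyl, with a 2.1-fold lower number from compound 2 to compound 4 (0.32 log units; beyond the scatter), a modest step but beyond the scatter, so fewer heavy atoms on this carbon go along with the best number so far. Nothing measured here tells why thiophen-3-yl does so well at this position.

The compounds shown leave open whether the ring sulfur itself counts or only the ring size, which furan-3-yl or plain phenyl would help to separate. Also open, as far as these compounds go, is how a ring with nitrogen, such as pyridin-3-yl, would fare on this carbon.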